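The compounds below may be only part of what the source reports. "The series", "measured", "known", "first", "only" and "open" are said of these compounds alone.

Measured so far in a functional assay on HO8910 cells (Homo sapiens) for inhibition, read by MTT assay, with a stated time of 24 h, tested at 1 ug/mL; on this read-out higher numbers stand for more inhibition of growth at the one concentration tested and lower numbers for less inhibition of growth

- compound 1 `O=C(CCCCC1CCSS1)Nc1cccc(C(F)(F)F)c1` gives 4.76%
- compound 2 `O=C(CCCCC1CCSS1)Nc1ccc(OC(F)(F)F)cc1` gives 10%
- compound 3 `O=C(CCCCC1CCSS1)Nc1ccc([N+](=O)[O-])c(C(F)(F)F)c1` gives 0.96%

In this assay compound 3 stands at 0.96% and lies within the scatter of both compound 1 and compound 2, so these three do not separate on the present numbers.

Compound 4 `O=C(CCCCC(S)CCS)Nc1ccc([N+](=O)[O-])c(C(F)(F)F)c1` carries 1,3-disulfanylpropyl in place of the ring-bearing group of compound 3, on a saturated chain carbon, four bonds along the chain from a carbonyl carbon. Among the measured compounds shown here, the counted difference is a group of 5 heavy atoms (3 carbon, 2 sulfur; no ring) in place of a group of 5 heavy atoms (3 carbon, 2 sulfur; one five-membered non-aromatic ring with 2 hetero atoms), on a saturated chain carbon, four bonds along the chain from a carbonyl carbon and it is the only change between the two.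

For the measured compounds named here, the single measured step, a number 3.8 percentage points lower from compound 1 to compound 3 (within the scatter), is nitro in place of hydrogen on an aromatic carbon. It lies elsewhere in the molecule and bears only weakly on this change. Going by the values given here, no measured compound has the open chain, so the series offers no direct precedent. Among the compounds with values here, with the only measured step, a number 3.8 percentage points lower from compound 1 to compound 3 (within the scatter), inside the scatter, no step beyond the scatter is expected, and the range is left wider on the upper side for lack of precedent.

The expected change is a number 7 percentage points higher from compound 3 to compound 4 (within the scatter) in this assay and would stay within the scatter.

For compound 4 the estimate is 8%, with an expected range from 0% to 25% at this single concentration.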

Compound 4, percent growth inhibition at one concentration: 1.17%
The estimate for compound 4 lay 6.8 percentage points above the measured number; the measured number falls inside the stated range.
By their numbers in this assay, from the lowest: compounds 3, 4, 1 and 2 (each within the scatter of the next).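

In this assay, among the compounds shown here, replacing the ring-bearing group with 1,3-disulfanylpropyl, on a saturated chain carbon, four bonds along the chain from a carbonyl carbon, gives a number 0.2 percentage points higher from compound 3 to compound 4 (within the scatter), which is the first reading of any change at this position. Losing the five-membered non-aromatic ring and gaining 2 hydrogen-bond donors therefore does not separate the two compounds at the one concentration tested, but compound 3 at 0.96% and compound 4 at 1.17% both show so little growth inhibition that a further loss could hardly be seen on this read-out. No measurement of any property of these compounds bears on this result.

The open chain is shown only on the core of compound 3, so it remains open whether the same change would read the same way on the core of compound 2, which stands at 10% in this assay. Also open, on these data alone, is whether a carboxylic acid, an amine or a longer chain at this carbon would move the number, and whether compound 3 and compound 4 would separate at a higher concentration.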